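Moving the cyclopropane from the linker to the acyl group

The source may report more compounds than this note shows. Statements on the series, on what has been measured and on what is new or still open speak of the compounds shown alone.

Measured compounds:
compound 1 `CCC(=O)NC[C@@H]1C[C@H]1c1cccc2c1C[C@@H](CCCCc1ccccc1)O2` — 1 nM
compound 2 `CC(C)C(=O)NC[C@@H]1C[C@H]1c1cccc2c1C[C@@H](CCCCc1ccccc1)O2` — 6 nM
compound 3 `CCNC(=O)NCCCc1cccc2c1C[C@@H](CCCCc1ccccc1)O2` — 9 nM

The three compounds were tested in an assay on NIH3T3 cells for binding affinity to melatonin receptor type 1A (Homo sapiens); on this read-out lower numbers stand for stronger inhibition and higher numbers for weaker inhibition. Compound 1 gives the lowest number of the three; compound 2 gives a 6.0-fold higher number from compound 1 to compound 2 (0.78 log units; beyond the scatter), and compound 3 gives a 9.0-fold higher number from compound 1 to compound 3 (0.95 log units; beyond the scatter).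

The unmeasured compound 4 `O=C(NCCCc1cccc2c1C[C@@H](CCCCc1ccccc1)O2)C1CC1` has the same atoms as compound 1, joined differently: 3-((cyclopropylcarbonyl)amino)propyl in place of 2-((propanoylamino)methyl)cyclopropyl on an aromatic carbon. For the measured compounds named here, two measured steps bear on this. The step of a 6.0-fold higher number from compound 1 to compound 2 (0.78 log units; beyond the scatter) shows that adding a methyl to the saturated chain carbon bound to the carbonyl carbon raises the number, and compound 4 also carries a carbonyl bound to a substituted saturated carbon, the cyclopropyl. The step of a 9.0-fold higher number from compound 1 to compound 3 (0.95 log units; beyond the scatter) shows that exchanging the 2-((propanoylamino)methyl)cyclopropyl for a three-carbon open chain raises the number, and compound 4 carries the same 3-aminopropyl arrangement. Both changes point in the same direction, so a higher number in this assay is expected for compound 4, larger than either single step but not certain to add up fully. The expected step is a 15-fold higher number from compound 1 to compound 4 (1.18 log units; beyond the scatter). Compound 4 is estimated at 15 nM, with a range from 4 nM to 60 nM.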

Compound 4, inhibition constant: 2 nM
For compound 4 the middle estimate is 7.5-fold (0.88 log units) above the measured one; the measured number lies below the stated range.
By their numbers in this assay, from the lowest: compounds 1 and 4 (each within the scatter of the next); then compounds 2 and 3 (each within the scatter of the next).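

In this assay the exchange of 2-((propanoylamino)methyl)cyclopropyl for 3-((cyclopropylcarbonyl)amino)propyl on the aromatic carbon gives a 2.0-fold higher number from compound 1 to compound 4 (0.30 log units; within the scatter) and so leaves no difference that the measurement can separate. The cyclopropane can therefore stand in the acyl group instead of the linker, and an open propyl linker is compatible with a number in the same range as that of compound 1. With the propyl linker held constant, the group on the carbonyl makes a measurable difference: cyclopropyl in place of ethylamino gives a 4.5-fold lower number from compound 3 to compound 4 (0.65 log units; beyond the scatter) in this assay, so the higher number of compound 3 cannot be read as a property of the open linker alone. No measurement shown here gives a reason for either step.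

On these data alone, it remains open whether larger acyl rings such as cyclobutyl, or branched acyl groups such as isopropyl, would hold up on the propyl linker as cyclopropyl does. Also open, as far as these compounds go, are how a longer chain in place of the propyl linker would read, and whether ethylamino on the carbonyl would cost as much on the cyclopropane linker of compound 1.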